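Acetamide replacement on the fused ring of compound 1

This account rests on a few compounds, and the source may have more. Where it says the series, first, only, none or still open, it means among the compounds named here.

Compound 1 `CC(C)c1noc(N2CCC(Oc3cc(N4CCc5cc(N6CC(O)CCC6=O)ccc54)ncn3)CC2)n1` gives, in an assay on CHO cells for agonist activity at Glucose-dependent insulinotropic receptor (Homo sapiens), read by a luciferase reporter and cAMP accumulation, with a stated time of 2 h (a higher number here means that more compound is needed for the effect, a lower number that less compound is needed), a value of 90 nM, the higher of the two numbers recorded in this series. Compound 2 `CC(C)SC(=O)N1CCC(Oc2cc(N3CCc4cc(S(C)(=O)=O)ccc43)ncn2)CC1` differs from it in more than one place and gives 3.2 nM in this assay; the gap between the two values lies beyond the usual scatter, but with two simultaneous changes nothing can be attributed to either change alone.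

Compound 3 `CC(=O)N(C)c1ccc2c(c1)CCN2c1cc(OC2CCN(c3nc(C(C)C)no3)CC2)ncn1` is the single-point variant of compound 1 under consideration: acetyl(methyl)amino in place of 5-hydroxy-2-oxopiperidin-1-yl on an aromatic carbon. The group that leaves carries a hydroxyl donor and a ring; the group that enters is an open-chain amide with no donor. No measured pair in the set isolates this change, so the expected step rests on the structural change alone and on the fact that compound 2, the only other number shown, carries a small acyclic substituent at the comparable place and gives 3.2 nM.

The expectation for the step from compound 1 to compound 3 is a modest decrease in the number, a 2.0-fold lower number from compound 1 to compound 3 (0.30 log units; within the scatter), though a move within the scatter would not surprise. Compound 3 is accordingly estimated at 45 nM, with a range from 12 nM to 180 nM.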

Compound 3, half-maximal effective concentration: 75 nM
Beside the measured number, compound 3's estimate is 1.7-fold (0.22 log units) below it; low and high end bracket the measured number.
By their numbers in this assay, from the lowest: compound 2; then compounds 3 and 1 (each within the scatter of the next).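

In this assay, within the data shown here, acetyl(methyl)amino in place of 5-hydroxy-2-oxopiperidin-1-yl on this aromatic carbon gives a 1.2-fold lower number from compound 1 to compound 3 (0.08 log units; within the scatter) and is the first single-place reading. At this position, the six-membered non-aromatic ring and the hydroxyl donor of compound 1 can therefore be exchanged for the open-chain amide of compound 3 with no difference beyond the scatter, even though the entering group is smaller by the heavy-atom counts. The steps from compound 2 to the other two compounds cannot be read, as it differs from each in more than one place, and nothing available accounts for the result.

Open, going by these compounds, is whether a primary amine, a carboxylic acid or a longer acyl chain such as butanoyl on this aromatic carbon would give a number outside the scatter of compound 1 and compound 3. Also open, on these data alone, is how much of the lower number of compound 2 belongs to the group at this position and how much to the other places in which it differs.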